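Removing one methoxy from a weakly cytotoxic pair

The compounds below may be only part of what the source reports. "The series", "measured", "known", "first", "only" and "open" are said of these compounds alone.

Of the compounds shown here, two have so far been measured in a functional assay on Caco-2 cells (Homo sapiens) for cytotoxicity, read by MTT assay, with a stated time of 24 h; a higher number here means a weaker inhibitor, a lower number a stronger inhibitor. Compound 1 `COc1ccc(C2CC(=O)c3cc(OC)c(OC)c(OC)c32)c(OC)c1OC` gives 206000 nM. Compound 2 `COc1cc(C2CC(=O)c3cc(OC)c(OC)c(OC)c32)cc(OC)c1OC` reaches only a limit of the assay, >= 250000 nM. On the numbers shown, compound 2 therefore stands at the limit of >= 250000 nM in this assay, at which 1 of the 2 values shown sits, and the two values are not far apart. Compound 3 `COc1cc2c(cc1OC)C(c1cc(OC)c(OC)c(OC)c1)CC2=O` has not yet been measured in this assay. It differs from compound 2 by hydrogen in place of methoxy on an aromatic carbon. Going by the values given here, no step between measured compounds is available here, so the size of the change can only be anticipated. Both measured values lie at the weak end, and compound 2 sits at the limit, so a single methoxy taken off the fused system of two rings is expected to move the number little, within or close to the scatter, with no clear direction. Compound 3 is therefore expected to give about 220000 nM, between 110000 nM and 400000 nM. The estimated step of an at least 1.1-fold lower number from compound 2 to compound 3 (0.05 log units; that floor lies within the scatter) is expected to be small, and a further limit-only result would not surprise.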

Compound 3, half-maximal inhibitory concentration: 140000 nM
Beside the measured number, compound 3's estimate is 1.6-fold (0.20 log units) above it; the measured number falls inside the stated range.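

In this assay, going by these compounds alone, hydrogen in place of methoxy on an aromatic carbon of the fused system of two rings gives the first step that can be read at this position: an at least 1.7-fold lower number from compound 2 to compound 3 (0.25 log units; that floor lies within the scatter). Compound 3 thus gives a number inside the measurable range of the assay rather than a further limit, so this one change, the loss of a methoxy that stands ortho to another methoxy group, is enough to make the comparison possible, although the printed floor of the step does not go beyond the scatter. The true size of the step remains unknown, and only a floor can be stated, because compound 2 stands at a limit and not at a number: the limit of >= 250000 nM in this assay, at which 1 of the 3 values shown sits.

The compounds shown leave open whether this position responds to anything other than the loss of methoxy, since no amine, hydroxyl, fluorine or longer chain such as ethoxy appears there. They also leave open whether taking away the other methoxy on the same aromatic ring, or changing the methoxy groups on the separate trimethoxy-bearing ring, would produce a step that clearly exceeds the scatter.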